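Half-life under a switch from oxazole to dimethylimidazole

The source may report more compounds than this note shows. Statements on the series, on what has been measured and on what is new or still open speak of the compounds shown alone.

The series shares one core, carried by compound 1 `CC(C)C(c1ncc[nH]1)c1ccc(-c2ccc3cccc(F)c3c2)[nH]c1=O`, compound 2 `CC(C)NC(=O)CC(c1ccc(-c2ccc3cccc(F)c3c2)[nH]c1=O)C(C)C` and compound 3 `CC(C)C(c1ncco1)c1ccc(-c2ccc3cccc(F)c3c2)[nH]c1=O`, and differs only in the group on a saturated chain carbon bound to an aromatic carbon and a saturated chain carbon. In an ADME assay on microsomes from liver (Homo sapiens) for metabolic stability (a lower number here means that the compound disappears faster, a higher number that the compound lasts longer), compound 1 gives only a limit of the assay, < 0.0667 h (the limit of < 0.0667 h in this assay, at which 1 of the 3 values shown sits). In this assay compound 2 gives 0.32 h and compound 3 gives 0.178 h; these two numbers are within the scatter of each other a 1.8-fold lower number from compound 2 to compound 3 (0.25 log units; within the scatter), so compound 3 stands beside compound 2 without any order between them. The two clear steps both start from compound 1: an at least 4.7-fold higher number from compound 1 to compound 2 (0.68 log units; beyond the scatter) and an at least 2.6-fold higher number from compound 1 to compound 3 (0.42 log units; beyond the scatter).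

The unmeasured compound 4 `Cc1nc(C(c2ccc(-c3ccc4cccc(F)c4c3)[nH]c2=O)C(C)C)[nH]c1C` differs from compound 3 by 4,5-dimethyl-1H-imidazol-2-yl in place of 1,3-oxazol-2-yl on a saturated chain carbon bound to an aromatic carbon and a saturated chain carbon. Within the data shown here, the step that bears on it is the one from compound 1 to compound 3, where the oxazole replaced the imidazole and the number rose beyond the scatter; compound 4 returns to an imidazole, now bearing methyl groups, so a fall beyond the scatter is expected, roughly undoing that gain, a 2.2-fold lower number from compound 3 to compound 4 (0.35 log units; beyond the scatter). Compound 4 is therefore estimated at 0.08 h, between 0.03 h and 0.25 h, with a fair chance that only a limit is reported.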

Compound 4, half-life: 0.268 h
For compound 4 the middle estimate is 3.4-fold (0.53 log units) below the measured one; measured number outside the range, above it.
By their numbers in this assay, from the lowest: compounds 3, 4 and 2 (each within the scatter of the next). At a limit, below all of these: compound 1.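

In this assay, the 4,5-dimethyl-1H-imidazol-2-yl group on this saturated chain carbon does not share the result of the unsubstituted 1H-imidazol-2-yl group, with an at least 4.0-fold higher number from compound 1 to compound 4 (0.60 log units; beyond the scatter) on this change. Among these compounds, an imidazole at this position is therefore not tied to the lowest half-life in the set, and the two methyl groups are the only difference between compound 1 and compound 4. Against the other two groups the dimethylimidazole shows no order, with a 1.5-fold higher number from compound 3 to compound 4 (0.18 log units; within the scatter) and a 1.2-fold lower number from compound 2 to compound 4 (0.08 log units; within the scatter) in the two comparisons, which leaves three quite different groups at this position within the scatter of one another.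

On these data alone, how far compound 1 lies from the others stays open, as its result is a limit of the assay: the limit of < 0.0667 h in this assay, at which 1 of the 4 values shown sits. Also open, as far as these compounds go, is whether a single methyl group on the imidazole would give the same result as two, and whether an ethyl group or a trifluoromethyl group there, or a carboxylic acid in place of the ring, would take the half-life beyond the level these three compounds share.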